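The compounds below may be only part of what the source reports. "The series", "measured", "known", "first", "only" and "open" are said of these compounds alone.

Among the compounds with values here, compound 2 `Cc1ccc(-c2cn(C[C@H](O)[C@H]3OC(=O)C(OCc4ccccc4)=C3OCc3ccccc3)nn2)cc1` holds the lower of the two numbers so far: in a functional assay on HepG2 cells (Homo sapiens) for antiproliferative activity, read by MTT assay, with a stated time of 72 h (a higher number here means a weaker inhibitor, a lower number a stronger inhibitor), compound 2 gives 8770 nM, whereas compound 1 `O=C1O[C@H]([C@@H](O)Cn2cc(C3CC3)nn2)C(OCc2ccccc2)=C1OCc1ccccc1` gives 38100 nM, and the step between them reads a 4.3-fold lower number from compound 1 to compound 2 (0.64 log units; beyond the scatter). Compound 3 `COc1ccc(-c2cn(C[C@H](O)[C@H]3OC(=O)C(OCc4ccccc4)=C3OCc3ccccc3)nn2)cc1` differs from compound 2 by methoxy in place of methyl on an aromatic carbon. Within the data shown here, no measured step exchanges one substituent on that six-membered ring for another; the only step recorded replaces the whole group at that position, so it bears on compound 3 only loosely. A step of a 1.1-fold lower number from compound 2 to compound 3 (0.04 log units; within the scatter) is therefore expected, within the scatter. Compound 3 is estimated at 8000 nM, between 3000 nM and 25000 nM.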

Compound 3, half-maximal inhibitory concentration: 46400 nM
Compound 3: middle estimate off by 5.8-fold (0.76 log units), on the low side, outside the stated range (above it).
By their numbers in this assay, from the lowest: compound 2; then compounds 1 and 3 (each within the scatter of the next).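

In this assay, the position para to a large group on the six-membered aromatic ring proves sensitive to a small exchange: methoxy in place of methyl gives a clear loss (a 5.3-fold higher number from compound 2 to compound 3 (0.72 log units; beyond the scatter)). The lower number of compound 2 therefore does not extend to every para-substituted phenyl group, as 4-methoxyphenyl stands level with cyclopropyl (a 1.2-fold higher number from compound 1 to compound 3 (0.09 log units; within the scatter)). Nothing on hand explains this difference. On these data alone, it remains open whether an ethyl group, a chlorine atom or an amine at this position would track methyl or methoxy.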